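Aryl substituent variation in a shared-core antagonist series

The compounds below may be only part of what the source reports. "The series", "measured", "known", "first", "only" and "open" are said of these compounds alone.

Measured so far in a functional assay on HEK293 cells for antagonist activity at melanin-concentrating hormone receptor 1 (Homo sapiens), read by FLIPR and calcium flux; a higher number here means a weaker inhibitor, a lower number a stronger inhibitor:
compound 1, `Cc1cc(N(C)C)nc(N[C@H]2CC[C@@H](NC(=O)c3ccc(Cl)cc3)CC2)n1`, gives 16 nM
compound 2, `Cc1cc(N(C)C)nc(N[C@H]2CC[C@@H](NC(=O)c3ccc(F)cc3)CC2)n1`, gives 25 nM

Among the measured compounds shown here, compound 2 stands highest of the two numbers; its nearest neighbour is compound 1, and the only step so far, a 1.6-fold higher number from compound 1 to compound 2 (0.19 log units; within the scatter), lies within the scatter, so the two compounds are not separated in this assay.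

Compound 3, `Cc1cc(N(C)C)nc(N[C@H]2CC[C@@H](NC(=O)c3ccc(OC(F)(F)F)cc3)CC2)n1`, is not yet measured. It differs from compound 2 by trifluoromethoxy in place of fluoro on an aromatic carbon. For the measured compounds named here, no measured step exchanges fluoro for trifluoromethoxy, so the size of this change is not known from the data. Going by the values given here, the one step that bears on the same aromatic carbon, a 1.6-fold higher number from compound 1 to compound 2 (0.19 log units; within the scatter), moved the number only within the scatter when one halogen replaced another. A shift beyond the scatter in either direction is therefore not expected; the estimated step is a 1.4-fold lower number from compound 2 to compound 3 (0.14 log units; within the scatter). Compound 3 is expected to give about 18 nM in this assay, with a range from 6 nM to 55 nM.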

Compound 3, half-maximal inhibitory concentration: 230 nM
The estimate for compound 3 lay 13-fold (1.11 log units) below the measured number; the measured number lies above the stated range.
By their numbers in this assay, from the lowest: compounds 1 and 2 (each within the scatter of the next); then compound 3.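

In this assay, the aromatic carbon para to a large group is not indifferent to its substituent: trifluoromethoxy in place of fluoro gives a 9.2-fold higher number from compound 2 to compound 3 (0.96 log units; beyond the scatter), and trifluoromethoxy in place of chloro gives a 14-fold higher number from compound 1 to compound 3 (1.16 log units; beyond the scatter). The exchange of one halogen for the other had stayed within the scatter, so the tolerance seen there with chloro and fluoro does not extend to trifluoromethoxy. No measurement at hand explains this loss of inhibitory strength.

Going by these compounds, with three compounds, it remains open whether the higher number goes with the oxygen or with the fluorines of trifluoromethoxy. Methoxy and trifluoromethyl on the same aromatic carbon would bear on that question, and a plain methyl group would show how a non-halogen substituent behaves there.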